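Pyridinyl in place of methylphenyl on a shared core

The source may report more compounds than this note shows. Statements on the series, on what has been measured and on what is new or still open speak of the compounds shown alone.

Measured so far:
compound 1 `CS(=O)(=O)c1ccc(-c2cnc3[nH]cc(-c4nnc(-c5ccccc5)o4)c(=O)c3c2)cc1` gives 0.53%
compound 2 `Cc1ccc(-c2nnc(-c3c[nH]c4ncc(-c5ccc(S(C)(=O)=O)cc5)cc4c3=O)o2)cc1` gives 7.47%

Both numbers come from a functional assay on HCT-116 cells (Homo sapiens) for inhibition, read by MTT assay, with a stated time of 24 h, tested at 2.5 uM; a lower number here means less inhibition of growth, a higher number more inhibition of growth at the concentration tested. Among the measured compounds shown here, compound 2 is one of only two compounds measured; its nearest neighbour is compound 1, and the difference between them, a number 6.9 percentage points higher from compound 1 to compound 2 (within the scatter), is a methyl in place of hydrogen on an aromatic carbon. Both compounds therefore show hardly any growth inhibition at the concentration tested.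

Compound 3 `CS(=O)(=O)c1ccc(-c2cnc3[nH]cc(-c4nnc(-c5cccnc5)o4)c(=O)c3c2)cc1` has not yet been measured. It differs from compound 2 in one place: pyridin-3-yl in place of 4-methylphenyl on an aromatic carbon. For the measured compounds named here, no measured step of this kind exists; the only known step, the methyl change from compound 1 to compound 2, stayed within the scatter, so there is no sign that a group at this position moves the number much. Because of 7.47% for compound 2 and the small step seen so far, compound 3 is expected to stay near the low values already seen, with a change of a number 3.5 percentage points lower from compound 2 to compound 3 (within the scatter). The estimate for compound 3 is 4%, expected between -6% and 15%.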

Compound 3, percent growth inhibition at one concentration: 4.32%
The estimate for compound 3 lay 0.3 percentage points below the measured number, and the stated range covers the measured number.
By their numbers in this assay, from the lowest: compounds 1, 3 and 2 (each within the scatter of the next).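

In this assay, putting pyridin-3-yl in place of 4-methylphenyl gives a number 3.2 percentage points lower from compound 2 to compound 3 (within the scatter), and putting it in place of phenyl gives a number 3.8 percentage points higher from compound 1 to compound 3 (within the scatter). Among the compounds shown here, this is the first change at this position that swaps the ring itself rather than adding a methyl to it: carbon-only rings give way to an aromatic ring with a ring nitrogen, which counts as a hydrogen-bond acceptor, and still neither step lies beyond the scatter. Nothing measured on these compounds says why the three numbers lie so close together.

All three compounds carry a six-membered aromatic ring at this place on the five-membered ring, so they leave open what a group of another kind, such as an amine, a carboxylic acid or a longer alkyl chain, would do to growth inhibition there. They also leave open whether pyridin-4-yl, a ring with the same atoms but its nitrogen elsewhere, would read any differently from pyridin-3-yl, and whether any change at this position can lift the number clear of the scatter.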